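Methyl for Amino on the Core of Compound 3

The compounds below may be only part of what the source reports. "The series", "measured", "known", "first", "only" and "open" are said of these compounds alone.

The measured compounds are:
compound 1, `C#CCOc1ccc(-c2cc(-c3ccccc3OCC#C)nc(-c3ccccc3)n2)cc1`, 14400 nM;
compound 2, `C#CCOc1ccc(-c2cc(-c3ccc(OCC#C)cc3)nc(-c3ccccc3)n2)cc1`, 12300 nM;
compound 3, `C#CCOc1ccc(-c2cc(-c3ccc(OCC#C)c(OC)c3)nc(N)n2)cc1`, 20000 nM.

All three were tested in an assay on BTI-TN-5B1-4 cells for inhibition of Amine oxidase [flavin-containing] B (Homo sapiens), read by fluorescence and Amplex Red, using microsomes, with a stated time of 30 min; on this read-out higher numbers stand for weaker inhibition and lower numbers for stronger inhibition. Among the measured compounds shown here, the one step between measured compounds that differ in one place is a 1.2-fold lower number from compound 1 to compound 2 (0.07 log units; within the scatter), a swap of one aryl group for another that leaves the rest of the core untouched. Compound 3 carries an amino group on its core, and its number sits within the scatter of both compound 1 and compound 2, so the three cannot be told apart on these data.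

Compound 4, `C#CCOc1ccc(-c2cc(-c3ccc(OCC#C)c(OC)c3)nc(C)n2)cc1`, differs from compound 3 by methyl in place of amino on an aromatic carbon. For the measured compounds named here, no measured step touches this position: the only step on hand, from compound 1 to compound 2, concerns a different part of the structure and was itself within the scatter. Nothing in the set therefore points to a change beyond the scatter in this assay, in either direction. Compound 4 is expected to give about 16000 nM, with a range of 5000 nM to 50000 nM, which is estimated as a 1.3-fold lower number from compound 3 to compound 4 (0.10 log units; within the scatter).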

Compound 4, half-maximal inhibitory concentration: 21100 nM
Compound 4: the middle estimate sits 1.3-fold (0.12 log units) below what was measured; the range from low to high includes it.
By their numbers in this assay, from the lowest: compounds 2, 1, 3 and 4 (each within the scatter of the next).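

In this assay, the position between two ring nitrogen atoms now has its first measured step, a 1.1-fold higher number from compound 3 to compound 4 (0.02 log units; within the scatter), with methyl in place of amino. Losing the hydrogen-bond donor and hydrogen-bond acceptor counted for amino thus leaves the number within the scatter, and compound 3 and compound 4 cannot be told apart at this position. No measurement at hand offers an explanation for this result.

The compounds shown leave open whether a dimethylamino group or a carboxylic acid on this carbon would also stay within the scatter. Among the compounds shown here, compound 1 and compound 2 carry phenyl here but differ from compound 3 and compound 4 in more than one place, so no single step isolates that group at this position.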